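The compounds below may be only part of what the source reports. "The series", "measured", "known", "first", "only" and "open" are said of these compounds alone.

Of the compounds shown here, three of this set have been measured so far, all on a shared core. Compound 1 `O=C(Nc1cccc(Oc2ccccn2)c1)C1CCCN(C(=O)c2cc(C(F)(F)F)cc(C(F)(F)F)c2)C1` gives 0% in an ADME assay on PC-3 cells (Homo sapiens) for cytotoxicity, read by WST assay, tested at 100 uM; on this read-out higher numbers stand for more inhibition at the one concentration tested (going by the name of the read-out) and lower numbers for less inhibition. Compound 2 `O=C(c1ccccc1)c1cccc(C(=O)N2CCCC(C(=O)Nc3ccc(Cl)cc3)C2)c1` gives 0% in this assay, and compound 3 `CCN(CC)S(=O)(=O)c1cccc(C(=O)N2CCCC(C(=O)Nc3ccc(Cl)cc3)C2)c1` gives 0% there as well. Within the data shown here, the single step measured between two of these, no change at the digits printed from compound 2 to compound 3 (within the scatter), left the read-out where it was, within the scatter. Compound 1 stands level with compounds 2 and 3 at the digits reported; its nearest neighbour is compound 2 and its furthest is compound 3, and neither gap reaches beyond the scatter. Nothing in the set has yet moved the read-out at all.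

Compound 4 `O=C(Nc1cccc(S(=O)(=O)N2CCCC2)c1)C1CCCN(C(=O)c2cc(C(F)(F)F)cc(C(F)(F)F)c2)C1` differs from compound 1 in one place: (pyrrolidin-1-yl)sulfonyl in place of (pyridin-2-yl)oxy on an aromatic carbon. Among the measured compounds shown here, no measured step touches this position, so the expectation rests on the flat behaviour of the whole set: the one measured step, a change of an aromatic substituent, produced no movement, and every value so far sits at the same reading. Compound 4 is therefore expected to give 0% in this assay, with a range of 0% to 10%. The expected step from compound 1 to compound 4 is no change at the digits printed from compound 1 to compound 4 (within the scatter), that is, none beyond the scatter.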

Compound 4, a percentage reported as inhibition, at one concentration (the size of the read-out at that concentration, not a potency): 0%
The estimate for compound 4 equals the measured number at the digits printed, within the range that was stated.
By their numbers in this assay, from the lowest: compounds 1, 2, 3 and 4 (each within the scatter of the next).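

In this assay, the place on an aromatic carbon, meta to a large group, now has a measured step of its own: putting (pyrrolidin-1-yl)sulfonyl in place of (pyridin-2-yl)oxy gave no change at the digits printed from compound 1 to compound 4 (within the scatter). Among these compounds, the earlier step lay elsewhere in the molecule, so this is the first reading at this place, and it shows that a quite different substituent leaves the read-out unmoved: a five-membered non-aromatic ring replaces a six-membered aromatic ring with 1 hetero atom, and the entering group brings sulfur and 2 double bonds outside aromatic rings, while the count of hydrogen-bond acceptors stays the same. No measurement offered here bears on why the read-out stayed where it did.

With all four compounds reading alike, these results cannot show which features at this place, if any, matter to the read-out, and they mark no group there as able to move it. On these data alone, whether a free amine or a carboxylic acid on the same aromatic carbon would shift the reading, or whether either would do so when the other end of the shared core is changed as well, remains open.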